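Bromo in Place of Hydrogen on the Core of Compound 1

The source may hold more compounds than are shown below. What is called first, only, known or untested is meant among the compounds shown, and "the series" means these compounds.

Measured so far:
compound 1 `O=C(/C=C/c1ccccc1)c1ccc[nH]1` gives > 100000 nM
compound 2 `O=C(/C=C/c1ccc([N+](=O)[O-])cc1)c1ccc[nH]1` gives 15000 nM
compound 3 `O=C(/C=C/c1cccc([N+](=O)[O-])c1)c1ccc[nH]1` gives 22000 nM

In a functional assay on MOLT-4 cells (Homo sapiens) for inhibition, read by MTT assay, with a stated time of 48 h (on this read-out lower numbers stand for stronger inhibition and higher numbers for weaker inhibition), compound 1 sits at the limit of > 100000 nM in this assay, at which 1 of the 3 values shown sits, a limit of the assay rather than a number. Compound 4 `O=C(/C=C/c1ccccc1Br)c1ccc[nH]1` differs from compound 1 in one place: bromo in place of hydrogen on an aromatic carbon. Going by the values given here, the only measured steps from compound 1 are an at least 6.6-fold lower number from compound 1 to compound 2 (0.82 log units; beyond the scatter) and an at least 4.5-fold lower number from compound 1 to compound 3 (0.65 log units; beyond the scatter), both lowering the number; they concern a nitro group at other places, not a bromo group, so they guide only loosely. A modest lowering is still the expectation, an at least 2.5-fold lower number from compound 1 to compound 4 (0.39 log units; beyond the scatter). Compound 4 is thus estimated at 40000 nM, within 10000 nM to 150000 nM, with a real chance that only a limit is reported again.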

Compound 4, half-maximal inhibitory concentration: 38000 nM
The estimate for compound 4 lay 1.1-fold (0.02 log units) above the measured number; low and high end bracket the measured number.
By their numbers in this assay, from the lowest: compounds 2, 3 and 4 (each within the scatter of the next, the first and the last beyond it). At a limit, above all of these: compound 1.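

In this assay, going by these compounds alone, the earlier steps involved only a nitro group, whereas this one shows that a bromo group, with 0 hydrogen-bond donors and 0 hydrogen-bond acceptors, also gives an at least 2.6-fold lower number from compound 1 to compound 4 (0.42 log units; beyond the scatter), here ortho to a group of 9 heavy atoms. The true size of this step stays unknown, as compound 1 gives only a limit of the assay: the limit of > 100000 nM in this assay, at which 1 of the 4 values shown sits.

On these data alone, it remains open whether a bromo group at other places on the same ring would give a similar step. Also open, as far as these compounds go, is what an amine or a carboxylic acid would do at this position.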